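The source may report more compounds than this note shows. Statements on the series, on what has been measured and on what is new or still open speak of the compounds shown alone.

Compound 1 `Clc1ccc(CNc2nc(/C=C/c3ccco3)nc3ccsc23)cc1` gives > 1000000 nM in a functional assay on L02 cells (Homo sapiens) for inhibition, read by Griess assay, with stated times of 1 h and 24 h (on this read-out lower numbers stand for stronger inhibition and higher numbers for weaker inhibition), which is a limit of the assay.
Compound 2 `COc1cc(/C=C/c2nc(Nc3ccc(C)cc3)c3sccc3n2)cc(OC)c1OC` gives < 40000 nM in this assay, also a limit of the assay.

Both measured values are limits rather than numbers. Compound 2 is known only to sit at the limit of < 40000 nM in this assay, at which 1 of the 2 values shown sits, and compound 1 only at the limit of > 1000000 nM in this assay, at which 1 of the 2 values shown sits. Among the compounds with values here, the two measured compounds differ from each other in more than one place, so no step between them can be counted; their values show only that compound 2 reaches the lower limit while compound 1 does not reach the upper one. Within the data shown here, compound 3 `COc1cc(/C=C/c2nc(NCc3ccccc3Cl)c3sccc3n2)cc(OC)c1OC` differs from compound 2 in a single change: 2-chlorobenzyl in place of 4-methylphenyl on a nitrogen on an aromatic ring With no measured step to lean on, the estimate rests on the limit of compound 2 alone. The step from compound 2 to compound 3 is expected to be a step that the limit leaves unreadable from compound 2 to compound 3, toward higher numbers, and it may well exceed the usual scatter. Compound 3 is therefore estimated at 30000 nM in this assay, with a range from 4000 nM to 250000 nM.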

Compound 3, half-maximal inhibitory concentration: > 1000000 nM
Compound 3: a limit, no number (the forecaster's own chance of this, stated with the estimate: 45%); at least 33-fold (1.52 log units) between middle value and limit.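

Within the data shown here, this is the first single change that can be read at this position: in this assay, 2-chlorobenzyl in place of 4-methylphenyl on a nitrogen on an aromatic ring gives an at least 25-fold higher number from compound 2 to compound 3 (1.39 log units; beyond the scatter). The earlier compounds shown here differed in more than one place and could not tie any difference to this nitrogen substituent, whereas here the rest of the molecule stays the same and the read-out still moves from one limit of the assay to the other, so this position is not indifferent to what it carries. With this change, compound 3 joins the upper end of the values shown: the limit of > 1000000 nM in this assay, at which 2 of the 3 values shown sit.

The change swaps several features at once, since 2-chlorobenzyl brings a chlorine and attaches its ring to the nitrogen differently from 4-methylphenyl, and the step cannot say which of these matters, nor how large it truly is, since both of its ends are limits. Plain benzyl or 4-methylbenzyl on the same nitrogen would be the groups to separate these features, and the compounds shown leave their effect open.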